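The compounds below may be only part of what the source reports. "The series", "measured", "known", "first", "only" and "open" are said of these compounds alone.

Among the measured compounds shown here, compound 1 `Nc1ccc2cccc(OCC3CCCC3)c2n1` is the only member of this pair with a numerical result: in an assay on cells with melanin-concentrating hormone receptor 1 (Homo sapiens) as the target, read by radioligand binding (on this read-out higher numbers stand for weaker inhibition and lower numbers for stronger inhibition), compound 1 gives 53 nM. Compound 2 `CC(CC(C)(C)C)Oc1cccc2ccc(N3CCCC3)nc12` returns only > 2000 nM in this assay, which is the limit of > 2000 nM in this assay, at which 1 of the 2 values shown sits, rather than a number. For the measured compounds named here, no measured step between two closely related compounds is available here. Compound 3 `Nc1ccc2cccc(OCC3CC3)c2n1` differs from compound 1 by cyclopropyl in place of cyclopentyl on a saturated chain carbon bound to an oxygen on an aromatic ring. The change is expected to cost some binding, a step of a 2.8-fold higher number from compound 1 to compound 3 (0.45 log units; beyond the scatter), somewhat beyond the usual scatter. Compound 3 is therefore estimated at 150 nM in this assay, with a range from 50 nM to 500 nM.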

Compound 3, half-maximal inhibitory concentration: > 2000 nM
Compound 3: only a limit was reported; the forecaster's own chance of this, stated with the estimate: 10%; middle value at least 13-fold (1.12 log units) away from the limit.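

With the shared core held fixed, cyclopropyl in place of cyclopentyl on a saturated chain carbon bound to an oxygen on an aromatic ring gives an at least 37-fold higher number from compound 1 to compound 3 (1.57 log units; beyond the scatter) in this assay. Among the compounds shown here, this place is therefore sensitive to the change from cyclopentyl to cyclopropyl, which the earlier compounds could not show. The reading for compound 3 is a limit and not a number: the limit of > 2000 nM in this assay, at which 2 of the 3 values shown sit.

Still open, on these data alone, is how the read-out runs with ring size, which cyclobutyl or cyclohexyl at this place would address. Also open, as far as these compounds go, is whether an open chain such as isobutyl can replace cyclopentyl.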